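A few compounds are considered here, and "the series" means these few. Any claim that something is new, unique, unknown or untested is made for them only; others in the source may bear on it.

Of the compounds shown here, three that share a core have been tested so far. In a functional assay on NCI-H460 cells (Homo sapiens) for inhibition, read by MTT assay (a higher number here means a weaker inhibitor, a lower number a stronger inhibitor), compound 3 (`CCOC(=O)c1c(NC(=O)CC#N)sc(C(=O)Nc2ccccc2)c1-c1ccccc1`) gives 490 nM and sits within the usual scatter of compound 1 (`CCOC(=O)c1c(N)sc(C(=O)Nc2ccc(Cl)cc2)c1-c1ccccc1`) at 380 nM so these two cannot be told apart. Compound 2 (`N#Cc1c(N)sc(C(=O)Nc2ccccc2)c1-c1ccccc1`) gives 9620 nM which is a far higher number than that of compound 3, well beyond the scatter, and so marks a much weaker inhibitor.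

Compound 4 (`CCOC(=O)c1c(N)sc(C(=O)Nc2ccccc2)c1-c1ccccc1`) has not been measured yet. It differs from compound 3 at a single place (hydrogen in place of (cyanomethyl)carbonyl on a nitrogen on an aromatic ring), where hydrogen takes the place of (cyanomethyl)carbonyl on a nitrogen on an aromatic ring, leaving a plain amino group.

Within the data shown here, no measured pair shows this change on its own, so any expectation is indirect. Compound 1 also carries a plain amino group and gives 380 nM in this assay which suggests that such a group can go with a strong result. Compound 2 goes against that reading, with a plain amino group and 9620 nM as its value. A small move towards a higher number is therefore expected (a 1.4-fold higher number from compound 3 to compound 4 (0.15 log units; within the scatter)), possibly none beyond the scatter. For compound 4 the estimated value is 700 nM (expected range 200 nM to 3000 nM).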

Compound 4, half-maximal inhibitory concentration: 8590 nM
Beside the measured number, compound 4's estimate is 12-fold (1.09 log units) below it; measured number above the stated range.
By their numbers in this assay, from the lowest: compounds 1 and 3 (each within the scatter of the next); then compounds 4 and 2 (each within the scatter of the next).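

Among these compounds, on this nitrogen on an aromatic ring, the (cyanomethyl)carbonyl group makes a large difference in this assay: removing it to leave a plain amino group gives an 18-fold higher number from compound 3 to compound 4 (1.24 log units; beyond the scatter), a large step that the earlier compounds could only hint at. The chloro on an aromatic carbon turns out to matter just as much, with hydrogen in its place giving a 23-fold higher number from compound 1 to compound 4 (1.35 log units; beyond the scatter), whereas ethoxycarbonyl in place of cyano gives a 1.1-fold lower number from compound 2 to compound 4 (0.05 log units; within the scatter) and so makes no clear difference; among compounds 1, 2 and 4, which all carry a plain amino group, the low number therefore appears only with the chloro present. Nothing measured here explains why either of these two groups has such an effect.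

Going by these compounds, it remains open whether the chloro and the (cyanomethyl)carbonyl group together on one compound would give a lower number than either does alone. Also open, on these data alone, is whether a plain acetyl group would serve on this nitrogen as well as (cyanomethyl)carbonyl does, and whether fluoro or methyl could stand in for the chloro.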